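This account rests on a few compounds, and the source may have more. Where it says the series, first, only, none or still open, it means among the compounds named here.

Compound 1, `CNC(=O)[C@@H]1C[C@H](N2CCc3c(cccc3OC)C2)CN1C(=O)c1ccc(CN)c(OC)c1`: 100 nM in an assay on isolated protein for inhibition of serine protease 1 (Homo sapiens), read by fluorescence; on this read-out higher numbers stand for weaker inhibition and lower numbers for stronger inhibition
Compound 2, `COc1cc(C(=O)N2C[C@@H](n3cc(C4CC4)nn3)C[C@H]2C(=O)N[C@H]2C[C@@H]2c2ccccc2)ccc1CN`: 960 nM in this assay

Of the two numbers in this assay, compound 1 stands lowest with 100 nM. Compound 2 gives 960 nM, a gap that lies beyond the usual scatter of repeated measurements, so compound 1 is the stronger inhibitor of the pair. The two structures differ in several places at once, so the gap cannot be tied to any single change.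

Compound 3, `CNC(=O)[C@@H]1C[C@H](N2CCc3c(cccc3OCCOC)C2)CN1C(=O)c1ccc(CN)c(OC)c1`, has not been measured in this assay. It differs from compound 1 in one place: methoxymethyl in place of hydrogen on a saturated chain carbon bound to an oxygen on an aromatic ring. Within the data shown here, no measured pair in this set carries the same change, so there is nothing in the data to show its direction. The step is expected to be small, a 1.5-fold higher number from compound 1 to compound 3 (0.18 log units; within the scatter), within the scatter. Compound 3 is therefore expected to give about 150 nM, with a likely range from 50 nM to 500 nM.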

Compound 3, half-maximal inhibitory concentration: 8 nM
Beside the measured number, compound 3's estimate is 19-fold (1.27 log units) above it; measured number outside the range, below it.
By their numbers in this assay, from the lowest: compound 3; then compound 1; then compound 2.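

Methoxymethyl in place of hydrogen on a saturated chain carbon bound to an oxygen on an aromatic ring gives a 13-fold lower number from compound 1 to compound 3 (1.10 log units; beyond the scatter) in this assay, so this place, on which the earlier compounds said nothing, accepts a longer chain and answers strongly to it. The same difference read one bond further out is methoxy to 2-methoxyethoxy, and this single pair is all that speaks for the change, so it stands as one observation and not as a trend. Nothing on hand says what lies behind the step.

From the compounds shown here alone, whether the step rests on the oxygen within the 2-methoxyethoxy chain or on the length of the chain alone stays open. A plain propoxy group would bear on that question, as would a longer chain with a further ether oxygen, or a chain ending in an amine or a carboxylic acid.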